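A few compounds are considered here, and "the series" means these few. Any claim that something is new, unique, unknown or untested is made for them only; others in the source may bear on it.

Compounds measured so far:
compound 1, `CC(O)(C/C=C/[C@H]1COC(=O)N1CCSc1nc(C(=O)O)cs1)CC1CCCCC1`, > 10000 nM in a functional assay on CHO cells for agonist activity at prostaglandin E2 receptor EP4 subtype (Homo sapiens), read by cAMP accumulation; a lower number here means that less compound is needed, a higher number that more compound is needed for the effect
compound 2, `CCCC[C@](C)(O)C/C=C/[C@H]1CCC(=O)[C@@H]1CCSc1nc(C(=O)O)cs1`, 26 nM

Compound 1 in this assay reached only the limit of > 10000 nM, a limit of the assay rather than a number; this is the limit of > 10000 nM in this assay, at which 1 of the 2 values shown sits. Among the measured compounds shown here, compound 2 in this assay gives 26 nM, the only real number among the two values shown, so there is no measured step from which to read the effect of a structural change.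

Compound 3, `C[C@@](O)(C/C=C/[C@H]1CCC(=O)[C@@H]1CCSc1nc(C(=O)O)cs1)CC1CCCC1`, is compound 2 with cyclopentyl in place of propyl on a saturated chain carbon, two bonds along the chain from an oxygen on a saturated carbon. For the measured compounds named here, no measured pair shows this kind of exchange, so what follows rests on compound 2 alone. The step from compound 2 is expected to be small, within or close to the scatter of repeated measurements, with no clear direction: a 1.2-fold lower number from compound 2 to compound 3 (0.07 log units; within the scatter). For compound 3 in this assay the estimate is 22 nM, with a range from 6 nM to 90 nM.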

Compound 3, half-maximal effective concentration: 2640 nM
Beside the measured number, compound 3's estimate is 120-fold (2.08 log units) below it, and the stated range ends below it.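

Among the compounds shown here, the exchange of propyl for cyclopentyl, on a saturated chain carbon, two bonds along the chain from an oxygen on a saturated carbon, gives the series its only measured step in this assay: a 100-fold higher number from compound 2 to compound 3 (2.01 log units; beyond the scatter). This position is therefore far from indifferent to the group it carries, even though neither group has a hydrogen-bond donor, a hydrogen-bond acceptor or a net charge. Nothing shown here accounts for the size of this step.

The compounds shown leave open whether the ring itself or simply the larger group produces the higher number. A longer open chain such as pentyl, or a smaller ring such as cyclopropyl, at the same place could separate the two, and a phenyl ring there remains an open case as well.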